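Pyrrolyl regioisomers on a bridged amine core

This account rests on a few compounds, and the source may have more. Where it says the series, first, only, none or still open, it means among the compounds named here.

Measured so far:
compound 1, `c1c[nH]c(-c2ccc3c(c2)C2CNCC3C2)c1` — 68 nM
compound 2, `CCc1nc2cc3c(cc2o1)C1CNCC3C1` — 12 nM

Compound 1 has the higher of the two numbers in an assay for binding affinity to Neuronal acetylcholine receptor; alpha4/beta2 (Rattus norvegicus); a higher number here means a weaker inhibitor, a lower number a stronger inhibitor; compound 2 sits at a lower value, and the gap between the two is beyond the scatter. Among the compounds with values here, no pair differing in a single place has been measured, so no single step in this assay is known.

Compound 3, `c1cc(-c2ccc3c(c2)C2CNCC3C2)c[nH]1`, differs from compound 1 by 1H-pyrrol-3-yl in place of 1H-pyrrol-2-yl on an aromatic carbon. The atoms are the same and only their joining changes. Within the data shown here, with no comparable step on record, the expectation rests on compound 1 alone: the step of a 1.2-fold higher number from compound 1 to compound 3 (0.07 log units; within the scatter) is expected to be small, likely within the scatter, with no clear direction. Compound 3 is therefore estimated at 80 nM in this assay, in the range 25 nM to 250 nM.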

Compound 3, inhibition constant: 120 nM
The estimate for compound 3 lay 1.5-fold (0.18 log units) below the measured number, within the range that was stated.
By their numbers in this assay, from the lowest: compound 2; then compounds 1 and 3 (each within the scatter of the next).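

In this assay, within the data shown here, 1H-pyrrol-3-yl in place of 1H-pyrrol-2-yl on the aromatic carbon gives a 1.8-fold higher number from compound 1 to compound 3 (0.25 log units; within the scatter) and is the first single-place step available for this series. At this position, therefore, the two pyrrolyl regioisomers cannot be separated in this assay, even though the same atoms are joined differently. No measurement on hand bears on the reason for this result.

On these data alone, only these two pyrrolyl attachments have been compared at this position, so it remains open whether the same insensitivity extends to a methyl group on the pyrrole nitrogen, a furan or a thiophene ring. As far as these compounds go, how a smaller substituent such as an amine, or a carboxylic acid or longer chain, would fare on the same aromatic carbon also remains open.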